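The source may hold more compounds than are shown below. What is called first, only, known or untested is meant among the compounds shown, and "the series" means these compounds.

Measured so far:

- compound 1, `Nc1ccc(S(=O)(=O)N2CCN(c3ncc(C(O)(C(F)(F)F)C(F)(F)F)cc3C#CC3CC3)CC2)cn1`: < 14 mL.min-1.g-1 in an ADME assay (liver) for metabolic stability, with Liver microsome (Homo sapiens) as the target, using microsomes and NADPH, with a stated time of 30 min, tested at 1 uM; on this read-out higher numbers stand for fast clearance and lower numbers for slow clearance
- compound 2, `CC(C)(C)n1cc(-c2cc(C(O)(C(F)(F)F)C(F)(F)F)cnc2N2CCN(S(=O)(=O)c3ccc(N)nc3)CC2)cn1`: 86 mL.min-1.g-1
- compound 3, `COc1ccc(-c2cc(C(O)(C(F)(F)F)C(F)(F)F)cnc2N2CCN(S(=O)(=O)c3ccc(N)nc3)CC2)cn1`: 25 mL.min-1.g-1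

Compound 1 stands at the bottom of this small set, and its value is a limit of this assay rather than a number (the limit of < 14 mL.min-1.g-1 in this assay, at which 1 of the 3 values shown sits). Compounds 2 and 3 each carry an aromatic ring where compound 1 has the 2-cyclopropylethynyl group, and both give higher numbers: an at least 6.1-fold higher number from compound 1 to compound 2 (0.78 log units; beyond the scatter) and an at least 1.7-fold higher number from compound 1 to compound 3 (0.25 log units; that floor lies within the scatter), where the second of these has a floor that lies within the scatter. Between them, a 3.4-fold lower number from compound 2 to compound 3 (0.54 log units; beyond the scatter).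

Compound 4, `Nc1ccc(S(=O)(=O)N2CCN(c3ncc(C(O)(C(F)(F)F)C(F)(F)F)cc3-c3ccc4scnc4c3)CC2)cn1`, is not yet measured in this assay. It differs from compound 1 in one place: 1,3-benzothiazol-5-yl in place of 2-cyclopropylethynyl on an aromatic carbon. The two measured steps that exchange the same 2-cyclopropylethynyl group for an aromatic ring both moved this read-out upward, so an upward step is the natural expectation for compound 4 as well, though its size is uncertain given the spread between compound 2 and compound 3. For compound 4 a step of an at least 2.8-fold higher number from compound 1 to compound 4 (0.45 log units; beyond the scatter) is therefore expected. The expected value for compound 4 is 40 mL.min-1.g-1, with a range from 14 mL.min-1.g-1 to 110 mL.min-1.g-1.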

Compound 4, intrinsic clearance in microsomes: 39 mL.min-1.g-1
For compound 4 the middle estimate is 1.0-fold (0.01 log units) above the measured one; low and high end bracket the measured number.
By their numbers in this assay, from the lowest: compounds 3 and 4 (each within the scatter of the next); then compound 2. At a limit, below all of these: compound 1.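

Among the compounds shown here, exchanging 2-cyclopropylethynyl for 1,3-benzothiazol-5-yl in this assay gives an at least 2.7-fold higher number from compound 1 to compound 4 (0.44 log units; beyond the scatter), so a group of two fused aromatic rings on this aromatic carbon also moves the read-out upward, and this floor lies clearly beyond the scatter, which the floor for the single ring of compound 3 did not. The choice of aromatic group still matters, but not evenly: the new group gives a 2.2-fold lower number from compound 2 to compound 4 (0.34 log units; beyond the scatter), whereas it gives a 1.6-fold higher number from compound 3 to compound 4 (0.19 log units; within the scatter), so compound 3 and compound 4 cannot be told apart here and compound 2 alone stands apart from both. Compound 1 remains at a limit of this assay, so the full size of each step away from it stays unknown: the limit of < 14 mL.min-1.g-1 in this assay, at which 1 of the 4 values shown sits.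

The compounds shown leave open whether a group with no aromatic ring at this position, such as an amine or a longer chain, would stay as low as compound 1. They also leave open whether a plain phenyl ring would fall with compound 3 and compound 4 or with compound 2.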